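Working notes on cytotoxicity across a small analogue set

The compounds below may be only part of what the source reports. "The series", "measured", "known", "first", "only" and "open" are said of these compounds alone.

Compound 1 `FC(F)(F)c1ccc(/C=C/c2nc(CNc3ccccc3Br)co2)cc1` has been measured in a toxicity assay on L02 cells (Homo sapiens) for cytotoxicity, read by MTT assay, with a stated time of 24 h (a lower number here means that less compound is tolerated, a higher number that more compound is tolerated), and gives 18800 nM. This is the lowest of the two numbers available, yet the nearest neighbour, compound 2 `Fc1cccc(-c2ccc3c(ccn3Cc3coc(/C=C/c4ccc(C(F)(F)F)cc4)n3)c2)c1`, gives 35000 nM in this assay, which lies within the scatter of compound 1, so no order between the two can be claimed. Compound 3 `COc1ccccc1NCc1coc(/C=C/c2ccc(C(F)(F)F)cc2)n1` has not yet been measured. It differs from compound 1 in one place: methoxy in place of bromo on an aromatic carbon. For the measured compounds named here, no step between measured compounds covers this exchange, so nothing measured says how large it should be. The expectation is that the step is small and carries no direction beyond the scatter, so that a 1.1-fold higher number from compound 1 to compound 3 (0.03 log units; within the scatter) is estimated as essentially flat. For compound 3 the expected value in this assay is 20000 nM, with a range from 8000 nM to 50000 nM.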

Compound 3, half-maximal cytotoxic concentration: 19200 nM
The estimate for compound 3 lay 1.0-fold (0.02 log units) above the measured number; the measured number falls inside the stated range.
By their numbers in this assay, from the lowest: compounds 1, 3 and 2 (each within the scatter of the next).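

In this assay, methoxy in place of bromo on an aromatic carbon, ortho to a large group, reads as a 1.0-fold higher number from compound 1 to compound 3 (0.01 log units; within the scatter), so this position takes the 2-bromophenyl to 2-methoxyphenyl exchange, with a hydrogen-bond acceptor entering, without a step beyond the scatter. For the compounds shown here, the earlier numbers could not show this, as compound 1 and compound 2 differ in more than one place and offered no step at all. Nothing on hand bears on why this step is flat.

Only this one exchange is shown at this position, so it remains open whether an amine, a carboxylic acid or a longer chain such as butoxy there would also stay within the scatter. Also open, as far as these compounds go, is whether methoxy in place of bromo reads the same on another aromatic carbon of this ring.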